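This account rests on a few compounds, and the source may have more. Where it says the series, first, only, none or still open, it means among the compounds named here.

Measured so far in a functional assay, read by spectrophotometry, with a stated time of 15 min; on this read-out lower numbers stand for stronger inhibition and higher numbers for weaker inhibition:
compound 1 `COc1ccc(-c2c3ccc4ccccc4c3nc3c2c(C)nc2c4ccccc4ccc32)cc1` gives 82.3 ug/mL
compound 2 `Cc1nc2c3ccccc3ccc2c2nc3c(ccc4ccccc43)c(-c3ccccc3S)c12` gives 49.6 ug/mL

Compound 2 stands at the low end of these two numbers in this assay, though the step of a 1.7-fold lower number from compound 1 to compound 2 (0.22 log units; within the scatter) lies within the scatter, so the two compounds are not separated by the data.

Compound 3 `Cc1ccc(-c2c3ccc4ccccc4c3nc3c2c(C)nc2c4ccccc4ccc32)cc1` is the next point in the series: 4-methylphenyl in place of 2-sulfanylphenyl on an aromatic carbon. Within the data shown here, the only measured step that bears on this exchange is a 1.7-fold lower number from compound 1 to compound 2 (0.22 log units; within the scatter), which swapped one aryl group for another at the same aromatic carbon and moved the number by an amount within the scatter. Compound 3 carries a 4-methylphenyl, and with one aryl exchange on this carbon already flat, no shift beyond the scatter is expected for a 1.4-fold higher number from compound 2 to compound 3 (0.15 log units; within the scatter). For compound 3 the expected value in this assay is 70 ug/mL, with an estimated range from 35 ug/mL to 140 ug/mL.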

Compound 3, half-maximal inhibitory concentration: 68.7 ug/mL
For compound 3 the middle estimate is 1.0-fold (0.01 log units) above the measured one; low and high end bracket the measured number.
By their numbers in this assay, from the lowest: compounds 2, 3 and 1 (each within the scatter of the next).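

In this assay, the aryl group on the carbon opposite the ring nitrogen changes with a 1.4-fold higher number from compound 2 to compound 3 (0.14 log units; within the scatter); 2-sulfanylphenyl, with its hydrogen-bond donor and acceptor, gives way to 4-methylphenyl, with neither, and the data do not separate the two compounds. The smaller exchange of methyl in place of methoxy on the same aryl group gives a 1.2-fold lower number from compound 1 to compound 3 (0.08 log units; within the scatter), so the three aryl groups shown remain unseparated in this assay. No measured evidence bears on why these exchanges leave the numbers within the scatter.

From the compounds shown here alone, whether an amine or a carboxylic acid on this phenyl ring would move the number beyond the scatter remains open. Also open, going by these compounds, is whether a non-aromatic group, such as a longer alkyl chain, could take the place of the aryl group on this carbon.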